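Swapping a Phenethyl Side Chain for a Short Alkene

The source may report more compounds than this note shows. Statements on the series, on what has been measured and on what is new or still open speak of the compounds shown alone.

The shared core carries a side chain bound through an oxygen on an unsaturated carbon, and how well cells tolerate each variant is read in an ADME assay on HEL cells (Homo sapiens) for cytotoxicity, with a stated time of 3 days; on this read-out higher numbers stand for lower toxicity in this test and lower numbers for higher toxicity in this test. Compound 1 `CCC1(Cc2ccccc2)OS(=O)(=O)C=C1OCc1ccc(OC)cc1` reports only a limit of the assay, > 200000 nM, and so gives no number. In this assay compound 2 `CCC1(Cc2ccccc2)OS(=O)(=O)C=C1OCCCc1ccccc1` gives 133000 nM. For the measured compounds named here, the step of an at least 1.5-fold lower number from compound 1 to compound 2 (0.17 log units; that floor lies within the scatter) is the only measured comparison, and its floor lies within the usual scatter, so it shows no real change. Compound 2 therefore holds the only number shown. The other entry is the limit of > 200000 nM in this assay, at which 1 of the 2 values shown sits.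

Compound 3 `CCC1(Cc2ccccc2)OS(=O)(=O)C=C1OCC=C(C)C` differs from compound 2 by 2-methylprop-1-en-1-yl in place of phenethyl on a saturated chain carbon bound to an oxygen on an unsaturated carbon. Going by the values given here, the only measured step that bears on it, an at least 1.5-fold lower number from compound 1 to compound 2 (0.17 log units; that floor lies within the scatter), exchanged one aromatic side chain for another and gave no sign that altering this side chain moves toxicity beyond the scatter. The estimated step is a 1.2-fold higher number from compound 2 to compound 3 (0.08 log units; within the scatter), in line with that reading. The expected value for compound 3 in this assay is 160000 nM, within a range from 70000 nM to 350000 nM.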

Compound 3, half-maximal cytotoxic concentration: 112000 nM
The estimate for compound 3 lay 1.4-fold (0.15 log units) above the measured number; measured number inside the range.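

For the compounds shown here, the new comparison is the first with a measured number at both ends, and it spans a large exchange on a saturated chain carbon bound to an oxygen on an unsaturated carbon. Phenethyl, with its six-membered aromatic ring and 8 heavy atoms, leaves, and 2-methylprop-1-en-1-yl, with no ring and 4 heavy atoms, enters; in this assay this gives a 1.2-fold lower number from compound 2 to compound 3 (0.07 log units; within the scatter) and so shows no real change on losing the aromatic ring from this side chain. The other new step, an at least 1.7-fold lower number from compound 1 to compound 3 (0.25 log units; that floor lies within the scatter), can be read only as a floor, and compound 1 remains a limit rather than a number: the limit of > 200000 nM in this assay, at which 1 of the 3 values shown sits.

The compounds shown leave open whether an amine, a carboxylic acid or a much longer alkyl chain at this place would move the number beyond the scatter. They also leave open whether changes elsewhere on the shared core would alter how well the cells tolerate these compounds.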